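This account rests on a few compounds, and the source may have more. Where it says the series, first, only, none or still open, it means among the compounds named here.

Measured compounds: compound 1 `O=c1n(Cc2cc3cnccc3n2CCCCF)c2cnccc2n1C1CC1` gives > 50000 nM; compound 2 `Cn1ccc(-n2c(=O)n(Cc3cc4cc(Cl)ccc4n3CCCC#N)c3cnccc32)n1` gives > 50000 nM.

In an ADME assay on HeLa cells (Homo sapiens) for cytotoxicity, read by ATP content, with a stated time of 3 days (on this read-out lower numbers stand for higher toxicity in this test and higher numbers for lower toxicity in this test), compound 1 is reported only as a limit, > 50000 nM. Compound 2 likewise reaches only a limit, > 50000 nM, in this assay. Both values sit at the limit of > 50000 nM in this assay, at which 2 of the 2 values shown sit, so compound 2 stands where every number shown stands. Compound 3 `N#CCCCn1c(Cn2c(=O)n(-c3ccncc3)c3ccncc32)cc2cc(Cl)ccc21` differs from compound 2 by pyridin-4-yl in place of 1-methyl-1H-pyrazol-3-yl on an aromatic nitrogen. Among the compounds with values here, no step between measured compounds is available here, so no change beyond the scatter is expected in this assay, in either direction. Compound 3 is estimated at 50000 nM, between 25000 nM and 100000 nM, which means an expected step of a number no higher from compound 2 to compound 3 (the limit leaves the size open).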

Compound 3, half-maximal cytotoxic concentration: > 50000 nM
Compound 3: only a limit was reported; the forecaster's own chance of this, stated with the estimate: 80%; the middle value sits exactly at the limit.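

No step from compound 2 to compound 3 can be read in this assay, since both values are limits: the limit of > 50000 nM in this assay, at which 3 of the 3 values shown sit.

The compounds shown leave open whether pyridin-4-yl and 1-methyl-1H-pyrazol-3-yl on the aromatic nitrogen differ at all in this read-out.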